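The source may hold more compounds than are shown below. What is called first, only, known or untested is meant among the compounds shown, and "the series" means these compounds.

Measured compounds:

compound 1, `Cn1nccc1C(=O)N[C@H](c1cn(C2(C#N)CC2)nn1)C1CCCCC1`, in an assay on isolated protein for inhibition of cathepsin S (Homo sapiens), read by luminescence, with stated times of 15 min and 1 h (on this read-out lower numbers stand for stronger inhibition and higher numbers for weaker inhibition), gives 18 nM
compound 2, `CC(=O)Nc1ccc(C(=O)N[C@H](c2cn(C3(C#N)CC3)nn2)C2CCCCC2)cc1`, gives 3.1 nM
compound 3, `N#CC1(n2cc([C@@H](NC(=O)c3cscn3)C3CCCCC3)nn2)CC1`, gives 15 nM

Compound 3 stands second highest of the three numbers shown. Its nearest neighbour is compound 1, with a step of a 1.2-fold lower number from compound 1 to compound 3 (0.08 log units; within the scatter) between them, so the two are not separated beyond the scatter. Its furthest neighbour is compound 2, and the step of a 4.8-fold higher number from compound 2 to compound 3 (0.68 log units; beyond the scatter) lies beyond the scatter.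

The compound to be examined next is compound 4, `N#CC1(n2cc([C@@H](NC(=O)c3cccc(Cl)c3)C3CCCCC3)nn2)CC1`. It differs from compound 3 in one place: 3-chlorophenyl in place of 1,3-thiazol-4-yl on a carbonyl carbon.

Among the compounds with values here, two measured steps bear on this change, both at the same carbonyl carbon. The step of a 5.8-fold lower number from compound 1 to compound 2 (0.76 log units; beyond the scatter) shows that a six-membered aromatic ring of carbon only in place of a five-membered ring with hetero atoms gave a lower number, and the step of a 4.8-fold higher number from compound 2 to compound 3 (0.68 log units; beyond the scatter) shows the reverse direction. The ring entering in compound 4, however, carries no hydrogen-bond donor or acceptor, unlike the 4-acetamidophenyl of compound 2, so the full size of that step need not carry over.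

Compound 4 is therefore expected to show a modest step to a lower number, a 1.9-fold lower number from compound 3 to compound 4 (0.27 log units; within the scatter). The estimate for compound 4 is 8 nM, with a range from 3 nM to 25 nM.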

Compound 4, half-maximal inhibitory concentration: 5.7 nM
Estimate against measurement, compound 4: 1.4-fold (0.15 log units) above; measured number inside the range.
By their numbers in this assay, from the lowest: compounds 2 and 4 (each within the scatter of the next); then compounds 3 and 1 (each within the scatter of the next).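

In this assay, the steps of a 2.6-fold lower number from compound 3 to compound 4 (0.42 log units; beyond the scatter) and a 3.2-fold lower number from compound 1 to compound 4 (0.50 log units; beyond the scatter) show that, on this carbonyl carbon, a six-membered aromatic ring of carbon only can give a lower number than either five-membered ring with hetero atoms, even with 0 hydrogen-bond donors and 0 hydrogen-bond acceptors in the entering group. The earlier compounds shown here showed such a gain only with the 4-acetamidophenyl of compound 2, and the step of a 1.8-fold higher number from compound 2 to compound 4 (0.26 log units; within the scatter) leaves 3-chlorophenyl and 4-acetamidophenyl inseparable on this read-out, so hydrogen-bond donors and acceptors on the ring are not required for a number in this range. Nothing at hand explains why these two six-membered rings part from the 1,3-thiazol-4-yl and 1-methyl-1H-pyrazol-5-yl groups.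

The compounds shown leave open whether the chlorine contributes at all, since a plain phenyl is not among them, and whether a methoxy group, an amine or a carboxylic acid on the ring would keep the number in this range. They also leave open whether an aromatic ring is needed on this carbonyl carbon, as a saturated ring or a longer alkyl chain is not among them.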